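Benzyl in place of ethoxy: from compound 1 to compound 4

The source may hold more compounds than are shown below. What is called first, only, known or untested is meant among the compounds shown, and "the series" means these compounds.

Measured so far in a functional assay on DU-145 cells (Homo sapiens) for antiproliferative activity, read by MTT assay, with a stated time of 72 h; a lower number here means a stronger inhibitor, a higher number a weaker inhibitor:
compound 1, `CCOc1ccccc1OCCSC(=S)N[C@H]1CCOC1=O`, gives 28300 nM.
compound 2, `O=C(COc1ccc(C(=O)/C=C/c2cccc(Cl)c2)cc1)N[C@H]1CCOC1=O`, gives 3700 nM.
compound 3, `O=C1OCC[C@@H]1NC(=S)SCCOc1ccc(Cl)cc1`, gives only a limit of the assay, > 64000 nM.

Among the two numbers shown, compound 1 stands highest; compound 2 gives the lower number, and the gap between them lies beyond the usual scatter. The third entry is not a number: compound 3 sits at the limit of > 64000 nM in this assay, at which 1 of the 3 values shown sits.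

Compound 4, `O=C1OCC[C@@H]1NC(=S)SCCOc1ccccc1Cc1ccccc1`, differs from compound 1 in one place: benzyl in place of ethoxy on an aromatic carbon. Going by the values given here, no step between two measured compounds that differ in one place is available here, so the size of this change must be guessed from compound 1 alone. A modest shift is expected, probably toward a lower number, but not far enough to be sure it exceeds the scatter.

Compound 4 is therefore expected to give about 15000 nM, with a range from 4000 nM to 60000 nM. The estimated step of a 1.9-fold lower number from compound 1 to compound 4 (0.28 log units; within the scatter) is a small one.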

Compound 4, half-maximal inhibitory concentration: > 64000 nM
Compound 4: a limit, no number (the forecaster's own chance of this, stated with the estimate: 20%); middle value at least 4.2-fold (0.63 log units) away from the limit.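

In this assay, compound 4 gives > 64000 nM, which is a limit of the assay and not a number. Benzyl in place of ethoxy on this aromatic carbon brings an at least 2.2-fold higher number from compound 1 to compound 4 (0.35 log units; beyond the scatter), so this single change at this position costs activity rather than adding to it. The true size of the loss cannot be read, because compound 4 stands at a limit that it shares with another compound: the limit of > 64000 nM in this assay, at which 2 of the 4 values shown sit.

Going by these compounds, what remains open is whether ethoxy is itself close to the best choice here, or whether a smaller methoxy or a longer propoxy chain would move the value of compound 1 away from 28300 nM. On these data alone, it is also open whether an amine or a hydroxyl on this same carbon would be tolerated any better than benzyl.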